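A Methyl Shifted Outward on the Pendant Phenyl

A few compounds are considered here, and "the series" means these few. Any claim that something is new, unique, unknown or untested is made for them only; others in the source may bear on it.

Compound 2 `COc1ccccc1N1CCN(CCCCC(=O)NCc2ccccc2-c2ccccc2)CC1` was tested in an assay on CHO-K1 cells for displacement of a labelled ligand from 5-hydroxytryptamine receptor 7 (Homo sapiens), read by scintillation counting (on this read-out higher numbers stand for weaker inhibition and lower numbers for stronger inhibition), where compound 2 gives 37.9 nM. For the measured compounds named here, that is the highest of the two numbers recorded so far, though its only neighbour, compound 1 `COc1ccccc1N1CCN(CCCCC(=O)NCc2ccccc2-c2ccccc2C)CC1`, lies within the scatter: in this assay compound 1 gives 26.1 nM, and the step of a 1.5-fold higher number from compound 1 to compound 2 (0.16 log units; within the scatter) amounts to hydrogen in place of methyl on an aromatic carbon. Compound 3 `COc1ccccc1N1CCN(CCCCC(=O)NCc2ccccc2-c2ccc(C)cc2)CC1` has not yet been measured. Relative to compound 2 it shows (methyl in place of hydrogen on an aromatic carbon); the methyl sits on an aromatic carbon of a six-membered aromatic ring of carbon only, para to a large group, so the pendant ring reads as phenyl to 4-methylphenyl. Going by the values given here, the single measured step that bears on this, a 1.5-fold higher number from compound 1 to compound 2 (0.16 log units; within the scatter), also concerned a methyl on an aromatic carbon of that ring and stayed within the scatter. No change beyond the scatter is therefore expected. The estimated step in this assay is a 1.3-fold lower number from compound 2 to compound 3 (0.10 log units; within the scatter). Compound 3 is expected to give about 30 nM, most likely between 12 nM and 75 nM.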

Compound 3, inhibition constant: 66.1 nM
Beside the measured number, compound 3's estimate is 2.2-fold (0.34 log units) below it, and the stated range covers the measured number.
By their numbers in this assay, from the lowest: compounds 1, 2 and 3 (each within the scatter of the next, the first and the last beyond it).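

On its own, putting a methyl on the pendant ring as 4-methylphenyl does not separate compound 3 from the unsubstituted phenyl of compound 2 in this assay (a 1.7-fold higher number from compound 2 to compound 3 (0.24 log units; within the scatter)). What the new compound adds is a first sign that the place of the methyl on this ring may matter: the same group as 2-methylphenyl in compound 1 and as 4-methylphenyl in compound 3 gives a modest gap beyond the scatter (a 2.5-fold higher number from compound 1 to compound 3 (0.40 log units; beyond the scatter)), with weaker inhibition for compound 3, even though neither compound stands clear of the unsubstituted compound 2. No supporting measurement is available to explain this difference between the two methyl placements.

Going by these compounds, whether a methoxy group, a chlorine atom or an amine in place of this methyl would keep compound 3's level of inhibition, or shift it beyond the scatter, remains open. On these data alone, it is also open whether the gap between 2-methylphenyl and 4-methylphenyl would persist with a longer chain in the shared core, since these three compounds share a single chain length.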